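A few compounds are considered here, and "the series" means these few. Any claim that something is new, unique, unknown or untested is made for them only; others in the source may bear on it.

Measured so far:
- compound 1 `COc1cccc2c1Oc1cc(O)c(O)cc1CCc1ccc(O)c(c1)Oc1ccc(cc1)CC2`: 2610 nM
- compound 2 `Oc1ccc2cc1Oc1ccc(cc1)CCc1cccc(O)c1Oc1ccc(cc1)CC2`: 10500 nM

In a functional assay on HeLa cells (Homo sapiens) for antiproliferative activity, read by MTT assay, with a stated time of 48 h (on this read-out higher numbers stand for weaker inhibition and lower numbers for stronger inhibition), compound 2 gives 10500 nM, the higher of the two numbers and so the weaker inhibition. The gap to compound 1 at 2610 nM lies beyond the scatter. Going by the values given here, with only two measured compounds, the series offers no pattern to rely on.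

The next compound is compound 3 `Oc1ccc2cc1Oc1ccc(cc1)CCc1cccc(O)c1Oc1ccc(cc1O)CC2`. It differs from compound 2 by one change, hydroxy in place of hydrogen on an aromatic carbon. Among the compounds with values here, no measured pair shows this change, so its size in this assay cannot be read directly from the data.

A small shift toward stronger inhibition is the working expectation, because compound 1 at 2610 nM is the only measured point on that side of compound 2, and it marks a plausible lower region. The expected step is modest and probably within the scatter: a 1.6-fold lower number from compound 2 to compound 3 (0.21 log units; within the scatter). The uncertainty is wide, and a shift in the opposite direction cannot be excluded.

For compound 3 the estimated value is 6500 nM, with an expected range of 2500 nM to 17000 nM.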

Compound 3, half-maximal inhibitory concentration: 27400 nM
Compound 3: the middle estimate sits 4.2-fold (0.62 log units) below what was measured, outside the stated range (above it).
By their numbers in this assay, from the lowest: compound 1; then compound 2; then compound 3.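

In this assay, going by these compounds alone, the first single-place comparison runs toward weaker inhibition: hydroxy in place of hydrogen on an aromatic carbon gives a 2.6-fold higher number from compound 2 to compound 3 (0.42 log units; beyond the scatter) for this one change. At this position, on a six-membered aromatic ring of carbon only, ortho to a fused ring and meta to a fused ring, the added hydroxy therefore costs activity rather than leaving it unchanged or improving it, a direction that the two earlier compounds could not show. No available measurement bears on why the step runs this way.

The compounds shown leave open whether a methoxy group, an amine or a carboxylic acid on the same aromatic carbon would stay close to compound 2 or lose activity as compound 3 does in this assay. They also leave open whether hydroxy in place of hydrogen at another aromatic carbon of the shared core would give a step of the same direction and size, so this single step supports no rule for the series.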